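Spiro pyrazolone dienones: moving a methyl on the aryl

A few compounds are considered here, and "the series" means these few. Any claim that something is new, unique, unknown or untested is made for them only; others in the source may bear on it.

Measured compounds:
Compound 1 `CC1=NN(c2ccc(C)cc2)C(=O)C12C=CC(=O)C=C2c1cccc(C)c1`: 22500 nM
Compound 2 `CC1=NN(c2ccc(Br)cc2)C(=O)C12C=CC(=O)C=C2c1ccc(C)cc1`: 27400 nM

Going by the values given here, the two measured compounds share one core and differ in two places at once, so no single-change step between them can be stated. In a functional assay on A549 cells (Homo sapiens) for antiproliferative activity, read by CCK-8 assay, with a stated time of 72 h (a higher number here means a weaker inhibitor, a lower number a stronger inhibitor), compound 1 gives 22500 nM, and in this assay compound 2 gives 27400 nM. Of the two numbers, that of compound 2 is not separated from that of compound 1 beyond the scatter, so the two stand together as weak inhibitors.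

Compound 3 `CC1=NN(c2ccc(Br)cc2)C(=O)C12C=CC(=O)C=C2c1cccc(C)c1` has not been measured. It differs from compound 2 in one place only: 3-methylphenyl in place of 4-methylphenyl on a double-bonded ring carbon. The same exchange of the methyl position on this aryl is part of what separates compound 1 from compound 2, yet those two also differ in the group on the other ring, and their numbers do not part beyond the scatter. Nothing here points to a direction, so compound 3 is expected to stay close to compound 2, with the step of a 1.1-fold lower number from compound 2 to compound 3 (0.06 log units; within the scatter) expected to lie within the scatter. Compound 3 is estimated at 24000 nM, in a range from 10000 nM to 60000 nM.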

Compound 3, half-maximal inhibitory concentration: 45400 nM
Compound 3: the middle estimate sits 1.9-fold (0.28 log units) below what was measured; the measured number falls inside the stated range.
By their numbers in this assay, from the lowest: compounds 1, 2 and 3 (each within the scatter of the next).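

In this assay, with the bromo group held fixed, the position of the methyl on this aryl can now be read alone: 3-methylphenyl in place of 4-methylphenyl on a double-bonded ring carbon gives a 1.7-fold higher number from compound 2 to compound 3 (0.22 log units; within the scatter), a step that stays within the scatter. The second single change, with 3-methylphenyl held fixed, is bromo in place of methyl on an aromatic carbon, and it gives a 2.0-fold higher number from compound 1 to compound 3 (0.30 log units; within the scatter), which the data also print as within the scatter, so neither change on its own parts the compounds in this assay. No further data bear on these results or on what lies behind them.

Going by these compounds, the three compounds cover only methyl moved on one aryl and methyl exchanged for bromo on the other, so it remains open whether an amine, a carboxylic acid or a methoxy group on either aryl would part from these numbers beyond the scatter. On these data alone, it also remains open whether a longer chain in place of the methyl on the shared core would do so.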